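One Ring Exchange Tried on Two Different Cores

The compounds below may be only part of what the source reports. "The series", "measured", "known", "first", "only" and "open" are said of these compounds alone.

Compound 2 `Cc1ccc(C2CNN=C2S(=O)(=O)CC2=NCCS2)cc1` and compound 3 `Cc1ccc(C2CNN=C2S(=O)(=O)CC2=NCCO2)cc1` share one core; compound 1 `O=S(=O)(CC1=NCCS1)C1C(c2ccccc2)=NOC1c1ccccc1` and compound 4 `O=S(=O)(CC1=NCCO1)C1C(c2ccccc2)=NOC1c1ccccc1` share another, and the difference between the two cores is not broken down here. In a functional assay, tested at 75 ug/mL (on this read-out lower numbers stand for a weaker effect and higher numbers for a stronger effect at the one concentration tested), compound 2 gives 42.2% and compound 3 gives 42.1%. Compound 3 carries a group of 5 heavy atoms (3 carbon, 1 nitrogen, 1 oxygen; one five-membered non-aromatic ring with 2 hetero atoms) in place of a group of 5 heavy atoms (3 carbon, 1 nitrogen, 1 sulfur; one five-membered non-aromatic ring with 2 hetero atoms), on a saturated chain carbon bound to a sulfonyl sulfur, and this change gave a number 0.1 percentage points lower from compound 2 to compound 3 (within the scatter). Compound 4 carries the same change on the second core, (a group of 5 heavy atoms (3 carbon, 1 nitrogen, 1 oxygen; one five-membered non-aromatic ring with 2 hetero atoms) in place of a group of 5 heavy atoms (3 carbon, 1 nitrogen, 1 sulfur; one five-membered non-aromatic ring with 2 hetero atoms), on a saturated chain carbon bound to a sulfonyl sulfur). In this assay compound 1 is reported as "not active" (no number reported). Because a number 0.1 percentage points lower from compound 2 to compound 3 (within the scatter) was within the scatter on the first core, the same exchange is expected to leave compound 4 close to where compound 1 stands, that is, without a clear effect. Compound 4 is therefore estimated at 8% in this assay, between 0% and 25%.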

Compound 4, a percentage reported as activity, at one concentration (the size of the read-out at that concentration, not a potency): 53.3%
The estimate for compound 4 lay 45.3 percentage points below the measured number, and the stated range ends below it.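

In this assay, within the data shown here, compound 1 is reported as "not active" (no number reported) and so no step from compound 1 to compound 4 can be read. The compounds shown leave open whether the ring exchange acts differently on the two cores. No available evidence bears on this result.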